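A Methoxy Removed Twice in an Antiproliferative Series

The source may hold more compounds than are shown below. What is called first, only, known or untested is meant among the compounds shown, and "the series" means these compounds.

Compound 1 `CCOC(=O)CN(Cc1ccccc1)c1nc(NCc2ccccc2)ncc1[N+](=O)[O-]` and compound 2 `CCOC(=O)CN(Cc1ccccc1)c1nc(NCc2cccc(OC)c2)ncc1[N+](=O)[O-]` share one core, while compound 3 `COC(=O)CN(C)c1nc(Nc2cccc(OC)c2)ncc1[N+](=O)[O-]` and the as yet unmeasured compound 4 `COC(=O)CN(C)c1nc(Nc2ccccc2)ncc1[N+](=O)[O-]` share another; the difference between the two cores is not broken down here. In a functional assay on A549 cells (Homo sapiens) for antiproliferative activity, read by MTT assay, with a stated time of 48 h (on this read-out higher numbers stand for weaker inhibition and lower numbers for stronger inhibition), compound 1 reaches only the limit of the assay, > 100000 nM. Compound 2 likewise gives only a limit, > 100000 nM, in this assay. Among the measured compounds shown here, compound 3 is the one compound with a number: in this assay compound 3 gives 31900 nM. The change from compound 2 to compound 1 is hydrogen in place of methoxy on an aromatic carbon, and its step, a step that the two limits leave unreadable from compound 2 to compound 1, cannot be read because of the limit of > 100000 nM in this assay, at which 2 of the 3 values shown sit. The same change, (hydrogen in place of methoxy on an aromatic carbon), leads from compound 3 to compound 4. Since the measured pair does not show the size of its step, the expectation for compound 4 rests on the value of compound 3 alone, 31900 nM, and on the usual scatter of the assay. The expected step of a 1.3-fold higher number from compound 3 to compound 4 (0.10 log units; within the scatter) is therefore taken as near zero. Compound 4 is estimated at 40000 nM, within 15000 nM to 120000 nM in this assay.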

Compound 4, half-maximal inhibitory concentration: > 100000 nM
Compound 4: only a limit was reported; the forecaster's own chance of this, stated with the estimate: 35%; middle value at least 2.5-fold (0.39 log units) from the limit.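

In this assay compound 4 gives only a limit, > 100000 nM. Set against compound 3, hydrogen in place of methoxy on an aromatic carbon thus gives an at least 3.1-fold higher number from compound 3 to compound 4 (0.49 log units; beyond the scatter), so in this core the change from 3-methoxyphenyl to phenyl weakens inhibition by a margin beyond the scatter, though the true size of the step remains unknown. This does not show that the change behaves alike in both cores, since the step between compound 2 and compound 1 cannot be read and offers neither support nor contradiction, with nearly every value in the series at the same limit: the limit of > 100000 nM in this assay, at which 3 of the 4 values shown sit.

The compounds shown leave open how much weaker compound 4 really is, as it has no number, and whether the methoxy itself matters or any group in that place would serve. From the compounds shown here alone, whether an amine or a hydroxy group in place of the methoxy, or a carboxylic acid in place of the ester, would give a readable value in this assay also remains open.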